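The source may hold more compounds than are shown below. What is called first, only, known or untested is meant among the compounds shown, and "the series" means these compounds.

Of the compounds shown here, two have so far been tested in a functional assay on DU-145 cells (Homo sapiens) for inhibition, read by sulforhodamine B assay, with a stated time of 48 h; on this read-out higher numbers stand for lower toxicity in this test and lower numbers for higher toxicity in this test. Going by the values given here, compound 1 `O=C(Nc1cccc(-n2cc(-c3ccncc3)c(-c3ccc(Cl)c(O)c3)n2)c1)Nc1ccc(Cl)c(Cl)c1` is the first of them. In this assay compound 1 gives > 32500 nM, which is a limit of the assay rather than a number. Compound 2 `COc1cc(-c2nn(-c3cccc(NC(=O)Nc4ccc(Cl)c(C(F)(F)F)c4)c3)cc2-c2ccncc2)ccc1Cl` is the second. In this assay compound 2 likewise gives > 32500 nM, again a limit and not a number. Compound 2 thus stands where the whole set stands at present, namely at the limit of > 32500 nM in this assay, at which 2 of the 2 values shown sit. Among the compounds with values here, no step between measured compounds can be sized, as nothing but limits has been recorded. Compound 3 `O=C(Nc1cccc(-n2cc(-c3ccncc3)c(-c3ccc(Cl)c(O)c3)n2)c1)Nc1ccc(Cl)c(C(F)(F)F)c1` is the compound that comes next, and it differs from compound 2 by hydrogen in place of methyl on an oxygen on an aromatic ring. On the evidence of compound 2 at > 32500 nM, compound 3 is expected to show no change beyond the scatter, an estimated step of a number no higher from compound 2 to compound 3 (the limit leaves the size open). Compound 3 is estimated at 32500 nM, within a range from 20000 nM to 60000 nM, most probably reported once more only as a limit.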

Compound 3, concentration lethal to 50% of the cells: 25100 nM
Estimate against measurement, compound 3: 1.3-fold (0.11 log units) above; the range from low to high includes it.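

In this assay, going by these compounds alone, compound 3 gives 25100 nM, the first real number in this set rather than a limit, so this family can register a lethal concentration within the range of the test. Hydrogen in place of methyl on the oxygen gives an at least 1.2-fold lower number from compound 2 to compound 3 (0.11 log units; that floor lies within the scatter), and trifluoromethyl in place of chloro on an aromatic carbon gives an at least 1.2-fold lower number from compound 1 to compound 3 (0.11 log units; that floor lies within the scatter); each of these is only a floor within the scatter, so neither change is shown to have a real effect, nor is either shown to have none. The true size of both steps stays unknown, since the other two values are limits of the assay: the limit of > 32500 nM in this assay, at which 2 of the 3 values shown sit.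

Going by these compounds, it remains open how far compound 1 and compound 2 truly lie from compound 3. Also open, on these data alone, is whether an amine or an ethoxy group in place of the hydroxy on that ring would alter the number.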